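This account rests on a few compounds, and the source may have more. Where it says the series, first, only, none or still open, it means among the compounds named here.

Compound 2 `O=c1oc2ccccc2c(N2CCN(c3ccc(F)cc3)CC2)c1CO` belongs to a small set that shares one core and varies only the group on an amine nitrogen in a ring. In a functional assay on A-375 cells (Homo sapiens) for inhibition, read by MTT assay, with a stated time of 24 h (on this read-out lower numbers stand for stronger inhibition and higher numbers for weaker inhibition), compound 2 gives 24700 nM. Compound 3 `O=c1oc2ccccc2c(N2CCN(c3cccc(C(F)(F)F)c3)CC2)c1CO`, carrying a trifluoromethylphenyl group at that position, gives 31900 nM, a number that sits within the usual scatter of the value of compound 2, so the two cannot be ordered. For compound 1 `CCN1CCN(c2c(CO)c(=O)oc3ccccc23)CC1`, with an ethyl group there, this assay reports only a limit, > 50000 nM, because the value sits at the limit of > 50000 nM in this assay, at which 1 of the 3 values shown sits. Going by the values given here, the one measured step, an at least 2.0-fold lower number from compound 1 to compound 2 (0.30 log units; that floor lies within the scatter), shows that an aryl group in place of ethyl brought the value down from the limit into the measurable range.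

Compound 4 `O=c1oc2ccccc2c(N2CCN(c3cccc(Cl)c3Cl)CC2)c1CO` is not yet measured. It differs from compound 2 by 2,3-dichlorophenyl in place of 4-fluorophenyl on an amine nitrogen in a ring. Among the compounds with values here, no measured step exchanges one aryl group for another here; the only guide is that compound 2 and compound 3 give values within the scatter of each other. Compound 4 is therefore expected to give 25000 nM, within a range of 10000 nM to 60000 nM, a step of a 1.0-fold higher number from compound 2 to compound 4 (0.01 log units; within the scatter) that is expected to stay within the scatter.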

Compound 4, half-maximal inhibitory concentration: 8450 nM
Compound 4: middle estimate off by 3.0-fold (0.47 log units), on the high side; the whole stated range lies above it.
By their numbers in this assay, from the lowest: compound 4; then compounds 2 and 3 (each within the scatter of the next). At a limit, above all of these: compound 1.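

In this assay, 2,3-dichlorophenyl in place of 4-fluorophenyl on the amine nitrogen in the ring gives a 2.9-fold lower number from compound 2 to compound 4 (0.47 log units; beyond the scatter), so the choice of aryl group at this position can move the value, which compound 2 and compound 3 could not show because they could not be ordered. Against ethyl, the 2,3-dichlorophenyl group gives an at least 5.9-fold lower number from compound 1 to compound 4 (0.77 log units; beyond the scatter), and unlike the earlier step from ethyl, this one clears the scatter. That size is only a floor, since the value of compound 1 is a limit: the limit of > 50000 nM in this assay, at which 1 of the 4 values shown sits.

On these data alone, it remains open whether a single chlorine on the phenyl group would serve as well as the two in 2,3-dichlorophenyl. Also open, as far as these compounds go, is how a benzyl group or a pyridine ring would fare on that nitrogen.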